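A few compounds are considered here, and "the series" means these few. Any claim that something is new, unique, unknown or untested is made for them only; others in the source may bear on it.

Measured in a functional assay on CCRF-CEM cells (Homo sapiens) for inhibition, with a stated time of 72 h; a higher number here means a weaker inhibitor, a lower number a stronger inhibitor:
- compound 1 `COC(=O)C[C@H](NC(=O)OC(C)(C)C)C(=O)N(Cc1ccccc1)C1(C(=O)NCc2ccccc2)CCN(Cc2ccccc2)CC1`: 19000 nM
- compound 2 `CCCCNC(=O)C1(N(Cc2ccccc2)C(=O)[C@H](CC(=O)OC)NC(=O)OC(C)(C)C)CCN(Cc2ccccc2)CC1`: 28000 nM
- compound 3 `CCC(C)N(C(=O)[C@H](CC(=O)OC)NC(=O)OC(C)(C)C)C1(C(=O)NCc2ccccc2)CCN(Cc2ccccc2)CC1`: 19000 nM

Compound 1 stands level with compound 3 at the digits shown, and compound 2 lies within the scatter of compound 1. The next compound, compound 4 `COC(=O)C[C@H](N)C(=O)N(Cc1ccccc1)C1(C(=O)NCc2ccccc2)CCN(Cc2ccccc2)CC1`, differs from compound 1 at another place: hydrogen in place of tert-butoxycarbonyl on an amine nitrogen. In short, it has hydrogen in place of tert-butoxycarbonyl on an amine nitrogen.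

Two measured steps start from compound 1. One puts propyl in place of phenyl, giving a 1.5-fold higher number from compound 1 to compound 2 (0.17 log units; within the scatter). The other puts sec-butyl in place of benzyl on an amide-type nitrogen, giving no change at the digits printed from compound 1 to compound 3 (within the scatter). Neither step touches the tert-butoxycarbonyl group, so they show how little those changes moved this assay but give no direct measure for this one. The size of the new step therefore remains uncertain, and a modest move towards a higher number is expected, with no change beyond the scatter also possible. The expected step is estimated as a 1.6-fold higher number from compound 1 to compound 4 (0.20 log units; within the scatter). In this assay, compound 4 is estimated at 30000 nM, with an expected range of 10000 nM to 80000 nM.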

Compound 4, half-maximal inhibitory concentration: 104000 nM
Compound 4: the middle estimate sits 3.5-fold (0.54 log units) below what was measured, and the stated range ends below it.
By their numbers in this assay, from the lowest: compounds 1, 3 and 2 (each within the scatter of the next); then compound 4.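

Replacing tert-butoxycarbonyl with hydrogen on the amine nitrogen gives a 5.5-fold higher number from compound 1 to compound 4 (0.74 log units; beyond the scatter) in this assay, the only step among these compounds that lies beyond the scatter. The changes leading to compound 2 and compound 3 stayed within the scatter, so this amine nitrogen is the one place shown where a change clearly yields a weaker inhibitor. No available measurement bears on why this step is so much larger.

Going by these compounds, it remains open whether any group on this nitrogen would hold the level of compound 1, such as acetyl or methoxycarbonyl, or whether tert-butoxycarbonyl is specifically needed. Also open, on these data alone, are whether the same replacement would have a similar effect on compound 2 and compound 3, and how a carboxylic acid in place of the methyl ester would read.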